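A few compounds are considered here, and "the series" means these few. Any claim that something is new, unique, unknown or untested is made for them only; others in the source may bear on it.

The measured compounds:
compound 1 `C=CC1=C(C(=O)O)C(c2ccc(OC)cc2)OC1` gives 44300 nM
compound 2 `C=CC1=C(C(=O)NC(C)(C)C)C(c2ccc(OC)cc2)OC1` gives > 100000 nM
compound 3 `C=CC1=C(C(=O)Nc2ccccc2)C(c2ccc(OC)cc2)OC1` gives > 100000 nM

All three share one core and differ only in the group on the carbonyl carbon. In a functional assay on HeLa cells (Homo sapiens) for cytotoxicity, read by MTT assay, with a stated time of 24 h (a lower number here means a stronger inhibitor, a higher number a weaker inhibitor), compound 1, the acid, gives 44300 nM. For compound 2 the result is a limit of the assay, > 100000 nM. For compound 3 the result is likewise a limit of the assay, > 100000 nM. Compound 3 thus stands at the weak end of the shown numbers, at the limit of > 100000 nM in this assay, at which 2 of the 3 values shown sit, and its step from the acid reads an at least 2.2-fold higher number from compound 1 to compound 3 (0.35 log units; beyond the scatter). The step between the two amides reads a step that the two limits leave unreadable from compound 2 to compound 3.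

Compound 4 `C=CC1=C(C(=O)NCC(C)C)C(c2ccc(OC)cc2)OC1` is a further amide of the same core: isobutyl in place of phenyl on an amide-type nitrogen. Going by the values given here, the steps that bear on this change are an at least 2.2-fold higher number from compound 1 to compound 2 (0.35 log units; beyond the scatter), an at least 2.2-fold higher number from compound 1 to compound 3 (0.35 log units; beyond the scatter) and a step that the two limits leave unreadable from compound 2 to compound 3. Both amides measured so far sit at the limit, and the exchange of tert-butyl for phenyl on the amide nitrogen gave no readable number. Compound 4 is therefore expected to sit near 120000 nM, with a range from 50000 nM to 300000 nM. The step this estimate implies, a step that the limit leaves unreadable from compound 3 to compound 4, is expected to be small, most likely another limit rather than a number.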

Compound 4, half-maximal inhibitory concentration: > 100000 nM
Compound 4: no number, only a limit; the forecaster's own chance of this, stated with the estimate: 70%; the middle value is on the limit's open side.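

With compound 4, an open chain, isobutyl, stands on the amide nitrogen in place of the phenyl of compound 3 and the tert-butyl of compound 2, and in this assay compound 4 gives > 100000 nM, which is a limit of the assay and not a number. Measured against the acid, the exchange of hydroxy for isobutylamino on the carbonyl carbon reads an at least 2.2-fold higher number from compound 1 to compound 4 (0.35 log units; beyond the scatter), which is the same direction as for the two earlier amides, so that all three amides shown now stand at one edge of the scale: the limit of > 100000 nM in this assay, at which 3 of the 4 values shown sit. The steps among the three amides cannot be read, as each of them joins two limits, and no order among these amides can be stated.

The compounds shown leave open whether any amide of the shared core gives a number in this assay, for instance one with a morpholine or a carboxylic acid at the end of a chain on the nitrogen. Going by these compounds alone, they also leave open whether a methyl ester would stay near the acid, compound 1, which gives 44300 nM and is the only number in the set.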